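Triazene series: cytotoxicity notes and one open compound

This account rests on a few compounds, and the source may have more. Where it says the series, first, only, none or still open, it means among the compounds named here.

Measured compounds:
compound 1 `FC(F)(F)c1cccc(/N=N/N2CCCC2)c1` – > 100000 nM
compound 2 `CN(C)CCCN(/N=N/c1ccccc1)c1cccc(C(F)(F)F)c1` – 38000 nM
compound 3 `c1ccc(/N=N/N2CCCC2)cc1` – > 100000 nM

In an ADME assay on MDBK cells (Bos taurus) for cytotoxicity, read by MTT assay, with a stated time of 96 h (on this read-out higher numbers stand for lower toxicity in this test and lower numbers for higher toxicity in this test), compound 1 gives > 100000 nM, which is a limit of the assay and not a number. Compound 3 likewise gives > 100000 nM in this assay, again a limit. Among the measured compounds shown here, compound 2 is the only one with a number, 38000 nM in this assay.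

From compound 1 to compound 3 the change is hydrogen in place of trifluoromethyl on an aromatic carbon. The step is a step that the two limits leave unreadable from compound 1 to compound 3, and this rests on the limit of > 100000 nM in this assay, at which 2 of the 3 values shown sit: both ends sit at the same limit, so no size can be read.

Compound 2 and compound 1 differ in more than one place; the difference between the two cores is not broken down here.

Compound 4 `CN(C)CCCN(/N=N/c1ccccc1)c1ccccc1` has no value yet in this assay. From compound 2 to compound 4 the change is hydrogen in place of trifluoromethyl on an aromatic carbon. This is the same kind of change as from compound 1 to compound 3, not the same: there the place is meta to a group of 7 heavy atoms, here it is meta to a large group.

The measured pair gives no readable size for this change, so the step from compound 2 to compound 4 is expected to be small, a 1.6-fold higher number from compound 2 to compound 4 (0.20 log units; within the scatter). For compound 4 a value of 60000 nM is estimated, with a range from 20000 nM to 150000 nM, and a fair chance that only a limit is reported.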

Compound 4, half-maximal cytotoxic concentration: 95000 nM
Estimate against measurement, compound 4: 1.6-fold (0.20 log units) below, within the range that was stated.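

In this assay, on the core of compound 2, hydrogen in place of trifluoromethyl on an aromatic carbon gives a 2.5-fold higher number from compound 2 to compound 4 (0.40 log units; beyond the scatter), a modest step and the only readable size for this change in the series. The same change on the core of compound 1 cannot be read, so the measured pair on that core neither supports nor contradicts carrying the step over, because both of its compounds sit at a limit of the assay and not at a number: the limit of > 100000 nM in this assay, at which 2 of the 4 values shown sit. The result therefore describes one core only: it shows that the change can move the read-out on the core of compound 2, but it does not show that a step of this size would appear on the core of compound 1, and one readable pair sets no pattern for the series.

The compounds shown carry only trifluoromethyl or hydrogen at this place on the aromatic ring, so the outcome with a nitrile, a chlorine atom or a methoxy group there remains open. Also open, on these data alone, is whether the step would hold on a core bearing a longer chain or a carboxylic acid in place of the chain of compound 2.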